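The source may report more compounds than this note shows. Statements on the series, on what has been measured and on what is new or still open speak of the compounds shown alone.

Measured so far:
Compound 1, `O=C(COc1ccc(C(=O)/C=C/c2cccc(Cl)c2)cc1)N[C@H]1CCOC1=O`: in a functional assay on MCF7 cells (Homo sapiens) for antiproliferative activity, read by MTT assay, with a stated time of 72 h (a lower number here means a stronger inhibitor, a higher number a weaker inhibitor), compound 1 gives 20900 nM.
Compound 2, `O=C(CNc1ccccc1)N[C@H]1CCOC1=O`: compound 2 reaches only a limit of the assay, > 64000 nM.
Compound 3, `O=C(COc1ccc(C(=O)/C=C/c2ccccc2)cc1)N[C@H]1CCOC1=O`: compound 3 likewise reaches only a limit of the assay, > 64000 nM.

Compound 1 and compound 3 differ in one place: chloro in place of hydrogen on an aromatic carbon. That change brings an at least 3.0-fold lower number from compound 3 to compound 1 (0.48 log units; beyond the scatter). The size of this step can only be read as a lower bound, because compound 3 sits at the limit of > 64000 nM in this assay, at which 2 of the 3 values shown sit.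

Compound 2 carries a different core from compound 3; the difference between the two cores is not broken down here. Compound 4, `O=C(CNc1ccccc1Cl)N[C@H]1CCOC1=O`, has not yet been measured. It differs from compound 2 by chloro in place of hydrogen on an aromatic carbon. Among the compounds with values here, this is the same kind of change as the one from compound 3 to compound 1, but not the same: there the chloro entered meta to a large group, here it enters ortho to a large group.

In this assay compound 4 is expected to give 40000 nM, estimated to lie between 15000 nM and 100000 nM. The expected step is an at least 1.6-fold lower number from compound 2 to compound 4 (0.20 log units; that floor lies within the scatter). This expectation rests on compound 1 and compound 3, where the same kind of change gave an at least 3.0-fold lower number from compound 3 to compound 1 (0.48 log units; beyond the scatter). Since compound 2 itself reports only a limit, there is a real chance that compound 4 will also return a limit rather than a number.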

Compound 4, half-maximal inhibitory concentration: > 64000 nM
Compound 4 was reported as a limit; the forecaster's own chance of this, stated with the estimate: 60%; at least 1.6-fold (0.20 log units) between middle value and limit.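

Compound 2 and compound 4 both stop at a limit in this assay, so no step between them can be read, and the chloro on the aromatic carbon shows no measurable size of effect here: the limit of > 64000 nM in this assay, at which 3 of the 4 values shown sit.

The compounds shown leave open whether a chloro ortho to a large group changes the number at all on the core of compound 2.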